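This account rests on a few compounds, and the source may have more. Where it says the series, first, only, none or still open, it means among the compounds named here.

Compound 1 `COc1ccc(/C=C2\CCN=C2c2cccnc2)cc1` — > 10000 nM
Compound 2 `Clc1ccc(/C=C2\CCN=C2c2cccnc2)cc1` — > 10000 nM

These are the two measured compounds. In an assay for displacement of a labelled ligand from Nicotinic acetylcholine receptor alpha8 subunit (Periplaneta americana), read by scintillation counting, with a stated time of 2 h, at 24 degrees C (on this read-out lower numbers stand for stronger inhibition and higher numbers for weaker inhibition), compound 1 gives > 10000 nM, which is a limit of the assay and not a number. In this assay compound 2 gives > 10000 nM, likewise a limit. The step that the two limits leave unreadable from compound 1 to compound 2 cannot be read, since both values sit at the limit of > 10000 nM in this assay, at which 2 of the 2 values shown sit. Compound 3 `CN(C)c1ccc(/C=C2\CCN=C2c2cccnc2)cc1` is not yet measured and differs from compound 2 by dimethylamino in place of chloro on an aromatic carbon. Within the data shown here, no measured step bears on this change with a readable size, so the expected step is a step that the limit leaves unreadable from compound 2 to compound 3, a change not beyond the scatter. Compound 3 is estimated at 20000 nM, ranging from 3000 nM to 100000 nM.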

Compound 3, half-maximal inhibitory concentration: 5490 nM
Estimate against measurement, compound 3: 3.6-fold (0.56 log units) above; measured number inside the range.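

With dimethylamino on the aromatic carbon para to a large group, the series gains its first readable number in this assay. In place of chloro the change gives an at least 1.8-fold lower number from compound 2 to compound 3 (0.26 log units; that floor lies within the scatter), and in place of methoxy it gives an at least 1.8-fold lower number from compound 1 to compound 3 (0.26 log units; that floor lies within the scatter). Both steps are only floors, as the other two values are limits of the assay: the limit of > 10000 nM in this assay, at which 2 of the 3 values shown sit.

Going by these compounds, the true size of either step stays open. So does whether an unsubstituted amino group or a diethylamino group at this place would give a readable number.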